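A few compounds are considered here, and "the series" means these few. Any claim that something is new, unique, unknown or untested is made for them only; others in the source may bear on it.

In an ADME assay on the whole organism (plasma) for pharmacokinetics, with Rattus norvegicus as the target, with a stated time of 24 h, at a dose of 10 mg/kg by the oral route (on this read-out higher numbers stand for higher exposure at the dose given and lower numbers for lower exposure), compound 1 `Cc1ccc2c(c1)c(-c1ccc[nH]c1=O)c(C(=O)NS(C)(=O)=O)n2Cc1cc(F)ccc1F` gives 10400 ng.h/mL and compound 2 `CCS(=O)(=O)NC(=O)c1c(-c2ccc[nH]c2=O)c2cc(C)ccc2n1Cc1cc(F)ccc1F` gives 5340 ng.h/mL, so these two values lie within the usual scatter of each other. Compound 3 `Cc1ccc2c(c1)c(-c1ccc[nH]c1=O)c(C(=O)NS(=O)(=O)C(C)C)n2Cc1cc(F)ccc1F` differs from compound 2 by one change, (methyl in place of hydrogen on a saturated chain carbon bound to a saturated chain carbon and a sulfonyl sulfur), which turns ethylsulfonyl into isopropylsulfonyl. For the measured compounds named here, the one measured step of a similar kind, a 1.9-fold lower number from compound 1 to compound 2 (0.29 log units; within the scatter), also puts methyl in place of hydrogen on a saturated chain carbon bound to a sulfonyl sulfur. On that evidence, the expected change is small and no larger than the scatter, at a 1.2-fold lower number from compound 2 to compound 3 (0.07 log units; within the scatter). The estimated value for compound 3 is 4500 ng.h/mL, with an expected range of 1800 ng.h/mL to 11000 ng.h/mL.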

Compound 3, area under the concentration-time curve: 3400 ng.h/mL
The estimate for compound 3 lay 1.3-fold (0.12 log units) above the measured number; measured number inside the range.
By their numbers in this assay, from the lowest: compounds 3, 2 and 1 (each within the scatter of the next, the first and the last beyond it).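

In this assay, the single methyl that turns ethylsulfonyl into isopropylsulfonyl gives (a 1.6-fold lower number from compound 2 to compound 3 (0.20 log units; within the scatter)), a step that cannot be told from scatter on its own. For the compounds shown here, putting isopropyl in place of methyl on the sulfonyl sulfur gives (a 3.1-fold lower number from compound 1 to compound 3 (0.49 log units; beyond the scatter)), the first step here beyond the scatter, so the difference only shows across the full span from methyl to isopropyl. Nothing measured here explains that step. Still open, on these data alone, is how a longer chain such as propyl, or a ring such as cyclopropyl or phenyl, on the sulfonyl sulfur would compare.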